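Swapping a methyl for a phenyl on compound 2

The source may report more compounds than this note shows. Statements on the series, on what has been measured and on what is new or still open speak of the compounds shown alone.

Measured in a functional assay on MCF7 cells (Homo sapiens) for cytotoxicity, read by MTT assay, with a stated time of 48 h; a lower number here means a stronger inhibitor, a higher number a weaker inhibitor:
Compound 1 `COc1cc(C2CC(COCc3cn(Cc4cc(-c5ccc(F)cc5)cnc4Cl)nn3)ON2C=O)cc(OC)c1OC`: 45700 nM
Compound 2 `COc1cc(C2=NOC(COCc3cn(Cc4cc(C)cnc4Cl)nn3)C2)cc(OC)c1OC`: 85500 nM

These two values lie within the usual scatter of each other, so compound 2 cannot be ranked against compound 1. Compound 3 `COc1cc(C2=NOC(COCc3cn(Cc4cc(-c5ccccc5)cnc4Cl)nn3)C2)cc(OC)c1OC` changes compound 2 in one place: phenyl in place of methyl on an aromatic carbon. Within the data shown here, no measured pair shows this change alone. Compound 1, with a different core and a fluorinated phenyl group, gives 45700 nM, so a large shift in this assay seems unlikely. The expected step is a 1.6-fold lower number from compound 2 to compound 3 (0.19 log units; within the scatter), toward a lower number but within the scatter. Compound 3 is estimated at 55000 nM, with an expected range of 20000 nM to 130000 nM.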

Compound 3, half-maximal inhibitory concentration: 14600 nM
For compound 3 the middle estimate is 3.8-fold (0.58 log units) above the measured one, and the stated range ends above it.
By their numbers in this assay, from the lowest: compound 3; then compounds 1 and 2 (each within the scatter of the next).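

In this assay, replacing methyl with phenyl at the aromatic carbon para to the chloro group gives a 5.9-fold lower number from compound 2 to compound 3 (0.77 log units; beyond the scatter) and so a stronger inhibitor. Among these compounds, this is the first step that clearly exceeds the scatter, and it shows that this position accepts a much larger group without loss of activity. Nothing available explains the gain. This single pair leaves open whether an intermediate group such as ethyl would give part of the same step. It also leaves open how an amine on the added phenyl would change the number.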